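Adding methoxy and hydroxy beside the nitro group

The source may hold more compounds than are shown below. What is called first, only, known or untested is meant among the compounds shown, and "the series" means these compounds.

Three compounds share one core and differ only in the aromatic group on the saturated ring carbon. Compound 1 `COc1ccc([C@@H]2[C@@H](Oc3ccccc3)C(=O)N2c2cc(OC)c(OC)c(OC)c2)cc1` gives 6900 nM in a functional assay on MCF7 cells (Homo sapiens) for antiproliferative activity, read by MTT assay, with stated times of 24 h and 72 h; on this read-out higher numbers stand for weaker inhibition and lower numbers for stronger inhibition. Compound 2 `COc1ccc([C@@H]2[C@@H](Oc3ccccc3)C(=O)N2c2cc(OC)c(OC)c(OC)c2)cc1[N+](=O)[O-]` gives 4100 nM; the step of a 1.7-fold lower number from compound 1 to compound 2 (0.23 log units; within the scatter) stays within the scatter. Compound 3 `COc1cc(N2C(=O)[C@@H](Oc3ccccc3)[C@H]2c2cccc([N+](=O)[O-])c2)cc(OC)c1OC` gives 30000 nM, the highest of the three numbers, beyond the scatter from both compound 1 and compound 2.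

Compound 4 `COc1ccc([C@@H]2[C@H](Oc3ccccc3)C(=O)N2c2cc(OC)c(OC)c(OC)c2)c([N+](=O)[O-])c1O` is not yet measured. Its change from compound 3 is a group of 12 heavy atoms (7 carbon, 1 nitrogen, 4 oxygen; one six-membered aromatic ring of carbon only) in place of a group of 9 heavy atoms (6 carbon, 1 nitrogen, 2 oxygen; one six-membered aromatic ring of carbon only), on a saturated ring carbon. Within the data shown here, no measured step matches this change exactly. Among the measured compounds shown here, the only single step, from compound 1 to compound 2, shows that adding a nitro group changes little. The values of compound 3 and compound 1 show that the aromatic group on that carbon can shift the number well beyond the scatter. Compound 4 carries a methoxy group and a nitro group, as compound 2 does, so the number is expected to move toward those of compound 1 and compound 2, a step of a 4.3-fold lower number from compound 3 to compound 4 (0.63 log units; beyond the scatter). Compound 4 is therefore estimated at 7000 nM, within 2000 nM to 25000 nM.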

Compound 4, half-maximal inhibitory concentration: 89000 nM
Compound 4: the middle estimate sits 13-fold (1.10 log units) below what was measured; measured number above the stated range.
By their numbers in this assay, from the lowest: compounds 2 and 1 (each within the scatter of the next); then compound 3; then compound 4.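

Replacing the 3-nitrophenyl group on the saturated ring carbon with this larger group, which also brings a hydrogen-bond donor, gives a 3.0-fold higher number from compound 3 to compound 4 (0.47 log units; beyond the scatter) in this assay. The earlier single step, a 1.7-fold lower number from compound 1 to compound 2 (0.23 log units; within the scatter), showed only a change within the scatter when a nitro group was added, whereas this change shows that a larger aromatic group at this position can push the number up, towards weaker inhibition. Nothing measured here accounts for this step.

The change from compound 3 to compound 4 alters several parts of the aromatic group at once, so the shares of the methoxy, the hydroxy and the shifted nitro group remain unresolved. Also open, on these data alone, is how the number would respond to an amine in place of the nitro group, or a carboxylic acid in place of the hydroxy.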